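The source may hold more compounds than are shown below. What is called first, only, known or untested is meant among the compounds shown, and "the series" means these compounds.

Of the compounds shown here, two have been measured in an assay on CHO cells for displacement of a labelled ligand from prostaglandin D2 receptor 2 (Homo sapiens), read by scintillation counting; on this read-out higher numbers stand for weaker inhibition and lower numbers for stronger inhibition. Compound 1 `Cc1ccc(S(=O)(=O)N(C)C(C)C)cc1C#Cc1cc(Cl)ccc1OCC(=O)O` gives 3.8 nM, the lower of the two numbers, while compound 2 `CN(C)S(=O)(=O)c1cccc(C#Cc2cc(Cl)ccc2OCC(=O)O)c1` gives 14 nM in this assay, a gap that lies beyond the usual scatter of such measurements. No change at a single place between these two measured compounds is available, so the step to compound 3 `Cc1ccc(S(=O)(=O)N(C)CC(C)C)cc1C#Cc1cc(Cl)ccc1OCC(=O)O` rests on the structural change alone. Compound 3 differs from compound 1 only in that (isobutyl in place of isopropyl on a sulfonamide nitrogen), leaving the rest of the shared core untouched. Among the compounds with values here, since no measured pair shows the effect of such a change, the expectation is a small step of a 1.3-fold higher number from compound 1 to compound 3 (0.12 log units; within the scatter), most likely none beyond the scatter, with a slight lean toward a weaker result. Compound 3 is therefore estimated at 5 nM, within a range of 2 nM to 15 nM.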

Compound 3, inhibition constant: 4.2 nM
The estimate for compound 3 lay 1.2-fold (0.08 log units) above the measured number, within the range that was stated.
By their numbers in this assay, from the lowest: compounds 1 and 3 (each within the scatter of the next); then compound 2.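

In this assay, the change from isopropyl to isobutyl on a sulfonamide nitrogen gives a 1.1-fold higher number from compound 1 to compound 3 (0.04 log units; within the scatter). Within the data shown here, this is the first comparison that differs in one place, and it shows that, with the rest of the core of compound 1 held constant, this position takes either of these two chains with no difference beyond the scatter. The data offer no explanation for this match between the two chains.

The compounds shown leave open how far this tolerance extends, since only these two chains can be compared at this place. Whether a longer chain, a cyclohexyl ring or a chain ending in an amine or a carboxylic acid on this sulfonamide nitrogen would keep the number in the same range remains an open question.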